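The compounds below may be only part of what the source reports. "The series", "measured", "known", "first", "only" and "open" are said of these compounds alone.

Measured in an ADME assay on the whole organism (Mus musculus, strain CD1) for pharmacokinetics, read by LC-MS, with a stated time of 24 h, at a dose of 1 mg/kg by the intravenous route; a higher number here means faster removal of the compound, a lower number slower removal:
Compound 1 `CCOc1cc2[nH]c(Cc3nn(CC(=O)O)c(=O)c4ccccc34)nc2cc1Cl`: 23.3 mL/min/kg
Compound 2 `C[C@H](C(=O)O)n1nc(Cn2cc3cc(OCC4CC4)c(Cl)cc3n2)c2ccccc2c1=O`: 9 mL/min/kg
Compound 3 `CCC(C(=O)O)c1nn(Cc2cn3cc(OCC4CC4)c(Cl)cc3n2)c2ccccc2c1=O`: 12 mL/min/kg

Only these three compounds have been measured in this assay, and they span a narrow stretch of values. Compound 1, at 23.3 mL/min/kg, lies within the usual scatter of compound 3, at 12 mL/min/kg. Compound 2, at 9 mL/min/kg, gives a lower number than compound 1, and that gap lies beyond the scatter.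

The next compound to be measured is compound 4 `O=C(O)Cn1nc(Cc2nc3cc(Cl)c(OCC4CC4)cc3[nH]2)c2ccccc2c1=O`. It differs from compound 1 by cyclopropyl in place of methyl on a saturated chain carbon bound to an oxygen on an aromatic ring, which turns ethoxy into cyclopropylmethoxy.

No pair of measured compounds differs in one place only, so the size of this step has not been shown directly. Compound 2 at 9 mL/min/kg and compound 3 at 12 mL/min/kg also carry cyclopropylmethoxy, but their cores differ from that of compound 1, so they offer only weak guidance. A small move towards slower removal is therefore expected, probably no larger than the scatter. The expected change is a 1.4-fold lower number from compound 1 to compound 4 (0.14 log units; within the scatter).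

For compound 4 the estimated clearance is 17 mL/min/kg, with an expected range from 8 mL/min/kg to 34 mL/min/kg.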

Compound 4, clearance in the Mus musculus assay: 18.3 mL/min/kg
For compound 4 the middle estimate is 1.1-fold (0.03 log units) below the measured one; the range from low to high includes it.
By their numbers in the Mus musculus assay, from the lowest: compounds 2, 3, 4 and 1 (each within the scatter of the next, the first and the last beyond it).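

Going by these compounds alone, in the Mus musculus assay this position can now be read directly for the first time, from a pair that differs in one place only: cyclopropyl in place of methyl on a saturated chain carbon bound to an oxygen on an aromatic ring gives a 1.3-fold lower number from compound 1 to compound 4 (0.10 log units; within the scatter) on the core of compound 1. Turning ethoxy into cyclopropylmethoxy, which adds heavy atoms and a three-membered ring of carbon, therefore leaves removal of the compound from the whole organism indistinguishable from what it was. The same change does register in a physicochemical assay for solubility, measured as thermodynamic solubility, at pH 7.4 (a lower number here means a less soluble compound, a higher number a more soluble compound), where compound 1 gives 917 ug/mL and compound 4 gives 395 ug/mL and the pair separates beyond the scatter: the measured solubility of compound 1, 917 ug/mL, and of compound 4, 395 ug/mL, a 2.3-fold lower number (0.37 log units; beyond the scatter).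

The compounds shown leave open whether so small a step in clearance holds on other cores, as compound 2 and compound 3 carry cyclopropylmethoxy but have no ethoxy partner on their own cores among the compounds shown. They also leave open how clearance and solubility would respond at this place to a longer chain, or to a chain ending in an amine or a carboxylic acid.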